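This account rests on a few compounds, and the source may have more. Where it says the series, first, only, none or still open, it means among the compounds named here.

Compound 1 `CCC(=O)N1N=C(c2ccccc2)CC1c1ccc(Cl)cc1`: 100000 nM
Compound 2 `CCC(=O)N1N=C(c2ccccc2)CC1c1ccc(C)cc1`: 100000 nM

Both measured compounds were run in an assay on isolated protein for inhibition of Amine oxidase [flavin-containing] B (Bos taurus); on this read-out higher numbers stand for weaker inhibition and lower numbers for stronger inhibition. Compound 1 gives 100000 nM, and compound 2 gives 100000 nM. On these numbers compound 1 stands level with compound 2 at the digits shown; the one measured step, no change at the digits printed from compound 1 to compound 2 (within the scatter), is a methyl in place of chloro on an aromatic carbon and stays within the scatter, so neither substituent on that ring shifts the read-out in this assay.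

Compound 3 `CCC(=O)N1N=C(c2ccc(F)cc2)CC1c1ccc(Cl)cc1` differs from compound 1 by fluoro in place of hydrogen on an aromatic carbon. The same difference, cut one bond further out, reads phenyl to 4-fluorophenyl. Within the data shown here, no measured step touches this ring directly; the only step available, no change at the digits printed from compound 1 to compound 2 (within the scatter), concerns the other aryl ring and shows no change. With the series flat at the digits shown and nothing pointing the other way, no movement beyond the scatter is expected for this assay, an estimated step of no change at the digits printed from compound 1 to compound 3 (within the scatter). Compound 3 is accordingly estimated at 100000 nM, with an expected range from 50000 nM to 100000 nM.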

Compound 3, half-maximal inhibitory concentration: 6310 nM
Beside the measured number, compound 3's estimate is 16-fold (1.20 log units) above it, outside the stated range (below it).
By their numbers in this assay, from the lowest: compound 3; then compounds 1 and 2 (each within the scatter of the next).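

Among these compounds, the phenyl ring of the core, which no earlier step touched, is the first place where this assay responds: phenyl to 4-fluorophenyl gives a 16-fold lower number from compound 1 to compound 3 (1.20 log units; beyond the scatter), while methyl in place of chloro on the other aryl ring gave no change at the digits printed from compound 1 to compound 2 (within the scatter). A single fluoro, one heavy atom placed on an aromatic carbon para to a large group, is enough for a step beyond the scatter, so the flat read-out of the first two compounds holds only for that one change and not for the molecule as a whole. Nothing measured on these compounds gives a reason for this step.

From the compounds shown here alone, only hydrogen and fluoro are compared at this carbon, so it remains open whether the step is particular to fluoro or would also appear with chloro, methoxy, an amine or a carboxylic acid there. Also open, going by these compounds, is whether the fluoro step carries over when methyl replaces chloro on the other aryl ring, or when a longer chain sits on the carbonyl.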